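Removing both methyls from the aryl amide of compound 3

This account rests on a few compounds, and the source may have more. Where it says the series, first, only, none or still open, it means among the compounds named here.

Three amides built on the shared core of compound 1 `O=C(/C=C/C(=O)N1C/C(=C\c2ccccc2)C(=O)/C(=C/c2ccccc2)C1)Nc1ccc([N+](=O)[O-])cc1` have been tested in a functional assay on CCRF-CEM cells (Homo sapiens) for cytotoxicity; on this read-out lower numbers stand for stronger inhibition and higher numbers for weaker inhibition. Compound 1 gives 40000 nM. Compound 2 `Cc1ccc(NC(=O)/C=C/C(=O)N2C/C(=C\c3ccccc3)C(=O)/C(=C/c3ccccc3)C2)cc1` gives 1100 nM in this assay, and compound 3 `Cc1ccc(NC(=O)/C=C/C(=O)N2C/C(=C\c3ccccc3)C(=O)/C(=C/c3ccccc3)C2)cc1C` gives 7100 nM. Compound 3 therefore holds the second highest of the three numbers: it stands a 5.6-fold lower number from compound 1 to compound 3 (0.75 log units; beyond the scatter) and a 6.5-fold higher number from compound 2 to compound 3 (0.81 log units; beyond the scatter).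

Compound 4 `O=C(/C=C/C(=O)N1C/C(=C\c2ccccc2)C(=O)/C(=C/c2ccccc2)C1)Nc1ccccc1` differs from compound 3 by phenyl in place of 3,4-dimethylphenyl on an amide-type nitrogen. Within the data shown here, two measured steps bear on this change. The step of a 36-fold lower number from compound 1 to compound 2 (1.56 log units; beyond the scatter) shows that the group on the amide nitrogen can shift the number a great deal, and the step of a 6.5-fold higher number from compound 2 to compound 3 (0.81 log units; beyond the scatter) shows that adding a methyl to that aryl group raised the number. Among the measured compounds shown here, no measured pair covers the removal of both methyls at once, so whether compound 4 lands nearer compound 2 or nearer compound 3 remains open. A step down beyond the scatter, though smaller than a 6.5-fold higher number from compound 2 to compound 3 (0.81 log units; beyond the scatter), is the expected outcome.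

Compound 4 is accordingly expected to give 3000 nM in this assay, with a range from 800 nM to 12000 nM. The expected step is a 2.4-fold lower number from compound 3 to compound 4 (0.37 log units; beyond the scatter).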

Compound 4, half-maximal inhibitory concentration: 1100 nM
The estimate for compound 4 lay 2.7-fold (0.44 log units) above the measured number; the measured number falls inside the stated range.
By their numbers in this assay, from the lowest: compounds 2 and 4 (each within the scatter of the next); then compound 3; then compound 1.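

Phenyl in place of 3,4-dimethylphenyl on the amide-type nitrogen gives a clear step in this assay (a 6.5-fold lower number from compound 3 to compound 4 (0.81 log units; beyond the scatter)), so the drawback of compound 3 lies in what it carries beyond the single methyl of compound 2, since the step from that single methyl to hydrogen shows no difference (no change at the digits printed from compound 2 to compound 4 (within the scatter)). The large step seen earlier with methyl in place of nitro is therefore matched when hydrogen takes the place of nitro (a 36-fold lower number from compound 1 to compound 4 (1.56 log units; beyond the scatter)), which shows that among these four compounds the gain does not depend on having a methyl there, and that compound 1 and compound 3 are the two that depart from the unsubstituted phenyl amide. The data offered here give no explanation for the size of any of these steps.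

The compounds shown leave open whether other groups on the phenyl ring, such as an amine, a carboxylic acid or a methoxy group, would behave like the methyl of compound 2 or like the nitro of compound 1. They also leave open whether a longer chain in place of the aryl group on the amide-type nitrogen would keep the number of compound 4.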